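Capping the Hydroxy Group of Compound 2

This account rests on a few compounds, and the source may have more. Where it says the series, first, only, none or still open, it means among the compounds named here.

In an ADME assay (a lower number here means that the compound disappears faster, a higher number that the compound lasts longer), compound 1 `COc1ccc(C[S+]([O-])c2ncccc2C(=O)Nc2ccncc2)c(OC)c1` gives < 0.02 h, which is a limit of the assay and not a number. Compound 2 `COc1ccc(C[S+]([O-])c2ncccc2C(=O)Nc2ccncc2)c(OCCO)c1` gives < 0.02 h, and this too is only a limit. Neither compound has a readable half-life, and their shared position is the limit of < 0.02 h in this assay, at which 2 of the 2 values shown sit.

Compound 3 `COCOCCOc1cc(OC)ccc1C[S+]([O-])c1ncccc1C(=O)Nc1ccncc1` has methoxymethyl in place of hydrogen on an oxygen on a saturated carbon, which turns 2-hydroxyethyl into 2-(methoxymethoxy)ethyl: methoxymethyl in place of hydrogen on an oxygen on a saturated carbon. Among the compounds with values here, the only measured step bearing on this is a step that the two limits leave unreadable from compound 1 to compound 2, so it offers no size to carry forward, and no step beyond the usual scatter is expected in either direction. The estimated step is a step that the limit leaves unreadable from compound 2 to compound 3. For compound 3, the expected half-life is 0.015 h, with an estimated range of 0.008 h to 0.04 h.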

Compound 3, half-life: < 0.02 h
Compound 3: no number, only a limit (the forecaster's own chance of this, stated with the estimate: 80%); the middle value does not contradict the limit.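

Within the data shown here, compound 1, compound 2 and compound 3 each give a limit and not a number, so no step between them can be read: the limit of < 0.02 h in this assay, at which 3 of the 3 values shown sit.

The compounds shown leave open how far apart their actual half-lives lie in this assay, and whether methoxymethyl in place of hydrogen changes the half-life at all.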